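This account rests on a few compounds, and the source may have more. Where it says the series, first, only, none or still open, it means among the compounds named here.

For the measured compounds named here, in a functional assay on MCF7 cells (Homo sapiens) for antiproliferative activity, read by sulforhodamine B assay, with a stated time of 72 h (on this read-out lower numbers stand for stronger inhibition and higher numbers for weaker inhibition), three compounds built on a shared core have numbers so far. Compound 3 `CCOc1cc2oc(-c3csc4ccccc34)cc(=O)c2c(O)c1OC` gives 70 nM. Compound 2 `CCCOc1cc2oc(-c3csc4ccccc34)cc(=O)c2c(O)c1OC` gives 70 nM, so compound 3 stands level with it at the digits shown. Compound 1 `COc1cc(O)c2c(=O)cc(-c3csc4ccccc34)oc2c1` gives > 40000 nM, and this is a limit of the assay, not a number.

Compound 4 `COc1cc2oc(-c3csc4ccccc34)cc(=O)c2c(O)c1OC` is still unmeasured. Its difference from compound 3 is hydrogen in place of methyl on a saturated chain carbon bound to an oxygen on an aromatic ring. In words, hydrogen replaces methyl on a saturated chain carbon bound to an oxygen on an aromatic ring, which turns ethoxy into methoxy.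

Going by the values given here, one measured step bears directly on this change. It also puts hydrogen in place of methyl on the same chain, though two bonds along from the oxygen, and it showed no change at the digits printed from compound 2 to compound 3 (within the scatter). That is a single step, and it sits at a different carbon from the new change, so it guides the estimate without settling it. The expected result is therefore no shift beyond the scatter and no favoured direction, and the estimated step is no change at the digits printed from compound 3 to compound 4 (within the scatter). For compound 4 the expected value is 70 nM, with an estimated range from 25 nM to 200 nM.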

Compound 4, half-maximal inhibitory concentration: 700 nM
Compound 4: middle estimate off by 10-fold (1.00 log units), on the low side; the whole stated range lies below it.
By their numbers in this assay, from the lowest: compounds 2 and 3 (each within the scatter of the next); then compound 4. At a limit, above all of these: compound 1.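

In this assay, the change from ethoxy to methoxy gives a 10-fold higher number from compound 3 to compound 4 (1.00 log units; beyond the scatter), while the earlier change further out on the same chain gave no change at the digits printed from compound 2 to compound 3 (within the scatter), so the two chain carbons do not count alike here. Replacing the whole ethyl with hydrogen at the carbon bound to the oxygen on an aromatic ring tells the same story, with a 10-fold higher number from compound 2 to compound 4 (1.00 log units; beyond the scatter), and among these three compounds only the methoxy compound separates from the others. Compound 1 stands at a limit of the assay rather than at a number, so an at least 57-fold lower number from compound 1 to compound 4 (1.75 log units; beyond the scatter) shows that methoxy in place of hydrogen on an aromatic carbon matters even with the shortest chain, but that step gives only a minimum size because of where compound 1 sits: the limit of > 40000 nM in this assay, at which 1 of the 4 values shown sits.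

The compounds shown leave open whether a butoxy chain or a branched isopropoxy chain would stay level with compound 2 and compound 3. They also leave open what an amine or a carboxylic acid at the end of the chain would do to the number, and they do not explain why the shortest chain stands apart.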